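The source may hold more compounds than are shown below. What is called first, only, known or untested is meant among the compounds shown, and "the series" means these compounds.

Measured compounds:
- compound 1 `CC(C)CSc1nnc2scc(-c3ccc(Cl)cc3)n12`: 256 nM
- compound 2 `N#Cc1ccc(NC(=O)NCc2cnc3scc(C#Cc4cccnc4)n23)cc1`: 3200 nM

Both were run in an assay on cells for inhibition of Indoleamine 2,3-dioxygenase 1 (Homo sapiens); a higher number here means a weaker inhibitor, a lower number a stronger inhibitor. Compound 2 stands at the higher of the two numbers; the gap to compound 1 lies beyond the usual scatter, so compound 2 is the weaker inhibitor of the pair. Among the measured compounds shown here, the two measured compounds differ in more than one place, so no single step between measured compounds can be read from them.

Compound 3 `N#Cc1ccc(NC(=O)NCc2cnc3scc(C#Cc4ccsc4)n23)cc1` is the next compound, not yet measured in this assay. It keeps the core of compound 2 and changes one place: thiophen-3-yl in place of pyridin-3-yl on a triple-bonded carbon. Nothing measured in this series speaks to that exchange, so the size and direction of the step in this assay are open; the working assumption is a step of no more than the usual scatter, if anything a slight shift toward a lower number. Compound 3 is therefore expected at 2500 nM, with a range of 900 nM to 7000 nM. That estimate means a step from compound 2 to compound 3 of a 1.3-fold lower number from compound 2 to compound 3 (0.11 log units; within the scatter), expected to stay within the scatter.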

Compound 3, half-maximal inhibitory concentration: 73.9 nM
Beside the measured number, compound 3's estimate is 34-fold (1.53 log units) above it, outside the stated range (below it).
By their numbers in this assay, from the lowest: compound 3; then compound 1; then compound 2.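

In this assay the group on the triple-bonded carbon is the one place in this series where a single exchange can be read, and the outcome is sensitive to it: thiophen-3-yl in place of pyridin-3-yl gives a 43-fold lower number from compound 2 to compound 3 (1.64 log units; beyond the scatter) with the rest of the structure unchanged. The exchange replaces a six-membered aromatic ring holding one nitrogen with a five-membered aromatic ring holding one sulfur, while the counts of hydrogen-bond donors and acceptors and the absence of net charge stay the same, so those counts do not separate the pair. No measurement at hand bears on the reason for a step of this size, which stands as an observation on this one pair.

Open, going by these compounds, is whether the lower number follows the sulfur, the five-membered ring or the absence of the pyridine nitrogen, a question that phenyl, furan-3-yl or thiophen-2-yl on the same triple-bonded carbon would help to separate. Also open, on these data alone, is whether the step holds with another group in place of the urea and its 4-cyanophenyl end.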